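This account rests on a few compounds, and the source may have more. Where it says the series, first, only, none or still open, it means among the compounds named here.

- compound 1 (`C/C(=N/NC(=O)c1cc(O)c(O)c(O)c1)c1cc(Br)ccc1O`) gives 1.14 ug/mL
- compound 2 (`C/C(=N/NC(=O)c1cc(O)c(O)c(O)c1)c1cc(Cl)ccc1O`) gives 1.14 ug/mL

In a functional assay, with a stated time of 30 min (on this read-out higher numbers stand for weaker inhibition and lower numbers for stronger inhibition), compound 2 stands at 1.14 ug/mL and is level with compound 1. Compound 3 (`COc1ccc(O)c(/C(C)=N\NC(=O)c2cc(O)c(O)c(O)c2)c1`) comes from compound 2 by methoxy in place of chloro on an aromatic carbon with the new group para to a hydroxy group. Going by the values given here, the one measured step at this place swaps one halogen for another. Among the compounds with values here, with no change at the digits printed from compound 1 to compound 2 (within the scatter) as the only guide, and no methoxy compound measured, no step beyond the scatter is expected in this assay and no direction is favoured. The expected change is a 1.1-fold higher number from compound 2 to compound 3 (0.02 log units; within the scatter) in this series. The estimate for compound 3 is 1.2 ug/mL with an expected range from 0.55 ug/mL to 2.6 ug/mL in this read-out.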

Compound 3, half-maximal inhibitory concentration: 1.14 ug/mL
Compound 3: the middle estimate sits 1.1-fold (0.02 log units) above what was measured, within the range that was stated.
By their numbers in this assay, from the lowest: compounds 1, 2 and 3 (each within the scatter of the next).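

Going from a halogen to a non-halogen at this place, para to a hydroxy group, in this assay gives no change at the digits printed from compound 2 to compound 3 (within the scatter) and no change at the digits printed from compound 1 to compound 3 (within the scatter). The place therefore accepts methoxy, with two heavy atoms and a hydrogen-bond acceptor, as well as chloro or bromo, a wider change than the halogen swap alone could show. No available evidence bears on why the read-out stays level. Still open, from the compounds shown here alone, is whether an amine, a carboxylic acid or a longer alkoxy chain here would keep this level, and whether plain hydrogen would.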